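Trimming the side chain of compound 3 to methylamino

The source may report more compounds than this note shows. Statements on the series, on what has been measured and on what is new or still open speak of the compounds shown alone.

In a functional assay on MCF7 cells (Homo sapiens) for cytotoxicity, read by MTT assay, with a stated time of 72 h (on this read-out lower numbers stand for stronger inhibition and higher numbers for weaker inhibition), three compounds on a shared core have been measured. Compound 1 `COc1ncc(-c2ccc3nc(NC(=O)N4CCCC4)nn3c2)cc1NS(=O)(=O)c1ccc(F)cc1` gives 1660 nM, compound 2 `CCCNC(=O)Nc1nc2ccc(-c3cnc(OC)c(NS(=O)(=O)c4ccc(F)cc4)c3)cn2n1` gives 360 nM and compound 3 `COc1ncc(-c2ccc3nc(NC(=O)NCC(=O)N4CCOCC4)nn3c2)cc1NS(=O)(=O)c1ccc(F)cc1` gives 630 nM. Compound 3 therefore holds the middle place by number alone, though its nearest neighbour cannot be separated from it: the gap is a 1.8-fold higher number from compound 2 to compound 3 (0.24 log units; within the scatter). The other gap is real, at a 2.6-fold lower number from compound 1 to compound 3 (0.42 log units; beyond the scatter).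

Compound 4 `CNC(=O)Nc1nc2ccc(-c3cnc(OC)c(NS(=O)(=O)c4ccc(F)cc4)c3)cn2n1` has not yet been measured. It is reached from compound 3 by hydrogen in place of (morpholin-4-yl)carbonyl on a saturated chain carbon bound to an amide-type nitrogen, which is hydrogen in place of (morpholin-4-yl)carbonyl on a saturated chain carbon bound to an amide-type nitrogen. The closest evidence is an exchange on that same carbon, (morpholin-4-yl)carbonyl in place of ethyl, which gave a 1.8-fold higher number from compound 2 to compound 3 (0.24 log units; within the scatter). Propylamino in place of pyrrolidin-1-yl on the carbonyl carbon gave a 4.6-fold lower number from compound 1 to compound 2 (0.66 log units; beyond the scatter), and compound 4 carries methylamino there. Neither step points to a large change, so no shift beyond the scatter is expected in this assay. The expected result is a 1.4-fold lower number from compound 3 to compound 4 (0.15 log units; within the scatter). For compound 4, the estimate is 450 nM, within an expected range of 170 nM to 1200 nM.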

Compound 4, half-maximal inhibitory concentration: 250 nM
Beside the measured number, compound 4's estimate is 1.8-fold (0.26 log units) above it; the range from low to high includes it.
By their numbers in this assay, from the lowest: compounds 4, 2 and 3 (each within the scatter of the next, the first and the last beyond it); then compound 1.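

In this assay, losing the (morpholin-4-yl)carbonyl from the saturated chain carbon bound to an amide-type nitrogen is a step beyond the scatter (a 2.5-fold lower number from compound 3 to compound 4 (0.40 log units; beyond the scatter)), while exchanging that group for ethyl had stayed within it (a 1.8-fold higher number from compound 2 to compound 3 (0.24 log units; within the scatter)). Hydrogen and ethyl on this carbon cannot be told apart (a 1.4-fold lower number from compound 2 to compound 4 (0.16 log units; within the scatter)), so among the three groups seen here, only the pair of hydrogen and (morpholin-4-yl)carbonyl is separated, and methylamino joins propylamino in standing apart from pyrrolidin-1-yl on the carbonyl carbon (a 6.6-fold lower number from compound 1 to compound 4 (0.82 log units; beyond the scatter)). No measurement at hand accounts for any of these steps.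

What the compounds shown leave open is whether a carboxylic acid, a primary amine or a longer chain such as butyl on the same chain carbon would fall with hydrogen and ethyl or with (morpholin-4-yl)carbonyl. On these data alone, it is also open whether dimethylamino on the carbonyl carbon would fall with compound 1 or with compound 4, a comparison that would show whether the ring of pyrrolidin-1-yl or the missing amide hydrogen goes with the gap.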